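Two Fluorines on the Phenyl of Compound 1

The source may report more compounds than this note shows. Statements on the series, on what has been measured and on what is new or still open speak of the compounds shown alone.

Measured so far:
compound 1 `O=C(O)Cc1sc(C(c2ccc(F)cc2)c2ccc(F)cc2)nc1-c1ccccc1` gives 240 nM
compound 2 `O=C(O)Cc1sc(C(c2ccccc2)c2ccc(O)cc2)nc1-c1ccc(F)cc1` gives 30 nM

Both numbers come from an in vitro functional assay on HEK285-7 cells for antagonist activity at prostaglandin D2 receptor 2 (Homo sapiens), read by BRET and beta-arrestin recruitment; on this read-out higher numbers stand for weaker inhibition and lower numbers for stronger inhibition. On this read-out compound 1 holds the highest of the two values; compound 2, the nearest, sits at a lower number, and the gap between them is beyond the usual scatter. Within the data shown here, compound 2 also differs from compound 1 in more than one place, so the two values show only that the pair differs, not which part is responsible.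

Compound 3 `O=C(O)Cc1sc(C(c2ccc(F)cc2)c2ccc(F)cc2)nc1-c1cc(F)cc(F)c1` is the untested neighbour of compound 1. The change is 3,5-difluorophenyl in place of phenyl on an aromatic carbon: the ring on the aromatic carbon of the core carries two fluorines, and nothing else moves. Among the measured compounds shown here, no measured pair isolates this change. For the measured compounds named here, from the one pair in hand, the expected step is a 2.0-fold lower number from compound 1 to compound 3 (0.30 log units; within the scatter). Compound 3 is therefore estimated at 120 nM, expected between 40 nM and 400 nM.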

Compound 3, half-maximal inhibitory concentration: 340 nM
Compound 3: the middle estimate sits 2.8-fold (0.45 log units) below what was measured; the measured number falls inside the stated range.
By their numbers in this assay, from the lowest: compound 2; then compounds 1 and 3 (each within the scatter of the next).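

In this assay the swap of phenyl for 3,5-difluorophenyl gives a 1.4-fold higher number from compound 1 to compound 3 (0.15 log units; within the scatter), a step within the usual scatter of repeated measurements. Unlike the earlier pair, which differed in more than one place, this pair isolates one change on the aromatic carbon next to the ring nitrogen, and the two added fluorines leave a read-out that cannot be told apart from that of the parent compound. No supporting data on record bear on this outcome.

Still open, from the compounds shown here alone, is whether this ring would tolerate a different kind of group just as well, such as an amine, a methoxy group or a carboxylic acid. Going by these compounds, it is also open whether the same two fluorines would give a similar result on a compound with a different large group on the shared core.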